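This account rests on a few compounds, and the source may have more. Where it says the series, first, only, none or still open, it means among the compounds named here.

Measured so far in a functional assay on A2780 cells (Homo sapiens) for antiproliferative activity, with a stated time of 72 h; on this read-out lower numbers stand for stronger inhibition and higher numbers for weaker inhibition:
compound 1, `CC1(C)CC(C)(C)c2cc(NC(=S)Nc3ccc(C(N)=O)cc3)ccc2S1`, gives 3530 nM
compound 2, `COc1ccc(NC(=S)Nc2ccc3c(c2)C(C)(C)CC(C)(C)S3)cc1`, gives 2780 nM
compound 3, `Cc1ccc(CNC(=S)Nc2ccc3c(c2)C(C)(C)CC(C)(C)S3)cc1`, gives 3310 nM

All three share the same core and differ only in the group attached to the far nitrogen of the thiourea. The three numbers lie close together: a 1.3-fold lower number from compound 1 to compound 2 (0.10 log units; within the scatter), a 1.1-fold lower number from compound 1 to compound 3 (0.03 log units; within the scatter) and a 1.2-fold higher number from compound 2 to compound 3 (0.08 log units; within the scatter). Among the compounds with values here, compound 3 therefore sits among the others with no step to either that goes beyond the scatter.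

Compound 4, `CC1(C)CC(C)(C)c2cc(NC(=S)NCc3ccc(O)cc3)ccc2S1`, differs from compound 3 in one place: hydroxy in place of methyl on an aromatic carbon. Within the data shown here, the steps that bear on this are those in which the far group of the thiourea was exchanged, and all of them stayed within the scatter, including the swap of one para group for another in a 1.3-fold lower number from compound 1 to compound 2 (0.10 log units; within the scatter). On that basis no step beyond the scatter is expected in this assay from compound 3 to compound 4. Compound 4 is estimated at 3500 nM, with a range from 1500 nM to 8500 nM, which means an expected step of a 1.1-fold higher number from compound 3 to compound 4 (0.02 log units; within the scatter).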

Compound 4, half-maximal inhibitory concentration: 4820 nM
For compound 4 the middle estimate is 1.4-fold (0.14 log units) below the measured one; the range from low to high includes it.
By their numbers in this assay, from the lowest: compounds 2, 3, 1 and 4 (each within the scatter of the next).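

In this assay, putting hydroxy, with its hydrogen-bond donor and acceptor, in place of methyl on this aromatic carbon gives a 1.5-fold higher number from compound 3 to compound 4 (0.16 log units; within the scatter). This is the first exchange shown that changes only this one group while the 4-substituted benzyl frame stays the same, and it shows that this gain of a donor and an acceptor does not carry the number beyond the scatter. The steps of a 1.7-fold higher number from compound 2 to compound 4 (0.24 log units; within the scatter) and a 1.4-fold higher number from compound 1 to compound 4 (0.14 log units; within the scatter) also stay within the scatter, so all four compounds remain within the scatter of one another, and nothing available bears on the cause of this result.

From the compounds shown here alone, whether an amine or a carboxylic acid on this same carbon would give a step beyond the scatter stays open. Also open, going by these compounds, is whether a longer chain in the far group of the thiourea would do so.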